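Compound 3 to compound 4: replacing the aryl group

This account rests on a few compounds, and the source may have more. Where it says the series, first, only, none or still open, it means among the compounds named here.

Measured in a functional assay on PC-9 cells (Homo sapiens) for antiproliferative activity, read by MTT assay; a higher number here means a weaker inhibitor, a lower number a stronger inhibitor:
Compound 1 `C#CCSc1nc(Sc2nccs2)c(C#N)c(-c2ccc(Br)cc2)n1`: 12100 nM
Compound 2 `C#CCSc1nc(Sc2nccs2)c(C#N)c(-c2ccc(Cl)cc2)n1`: 4130 nM
Compound 3 `C#CCSc1nc(Sc2nccs2)c(C#N)c(-c2ccc(C)cc2)n1`: 1110 nM

Compound 3 has the lowest number of the three, at 1110 nM. Compound 4 `C#CCSc1nc(Sc2nccs2)c(C#N)c(-c2ccc[nH]2)n1` carries 1H-pyrrol-2-yl in place of 4-methylphenyl on an aromatic carbon. The nearest evidence is a 3.7-fold lower number from compound 2 to compound 3 (0.57 log units; beyond the scatter), modest, and an 11-fold lower number from compound 1 to compound 3 (1.04 log units; beyond the scatter), large, with a 2.9-fold lower number from compound 1 to compound 2 (0.47 log units; beyond the scatter) also modest. All three change only one substituent on the aryl ring, and none replaces the ring, so they offer only a rough guide to size. A modest step to a higher number is expected in this assay, an estimated 2.7-fold higher number from compound 3 to compound 4 (0.43 log units; beyond the scatter). The expected value for compound 4 is 3000 nM, with an estimated range of 500 nM to 15000 nM.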

Compound 4, half-maximal inhibitory concentration: > 20000 nM
Compound 4: only a limit was reported (the forecaster's own chance of this, stated with the estimate: 10%); middle value at least 6.6-fold (0.82 log units) away from the limit.
By their numbers in this assay, from the lowest: compound 3; then compound 2; then compound 1. At a limit, above all of these: compound 4.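

In this assay compound 4 gives only a limit, not a number: the limit of > 20000 nM in this assay, at which 1 of the 4 values shown sits. Replacing the whole aryl ring with 1H-pyrrol-2-yl at this position, rather than changing its substituent, gives an at least 18-fold higher number from compound 3 to compound 4 (1.25 log units; beyond the scatter) (large) and an at least 4.8-fold higher number from compound 2 to compound 4 (0.68 log units; beyond the scatter) (at least modest). The remaining step is an at least 1.6-fold higher number from compound 1 to compound 4 (0.21 log units; that floor lies within the scatter) and cannot be read.

The compounds shown do not separate the five-membered ring from the added hydrogen-bond donor as the feature that matters. Thiophen-2-yl or 1-methylpyrrol-2-yl at this position would pull the two apart.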